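The source may report more compounds than this note shows. Statements on the series, on what has been measured and on what is new or still open speak of the compounds shown alone.

Compound 1 `Nc1nc2c(c(-c3cccs3)cn2[C@@H]2O[C@H](CO)[C@@H](O)[C@H]2O)c(=O)[nH]1` in a functional assay on HCT-116 cells (Homo sapiens), read by MTT assay, with a stated time of 72 h (on this read-out lower numbers stand for stronger inhibition and higher numbers for weaker inhibition), gives > 20000 nM, a limit of the assay and not a number. Compound 2 `CSc1ncnc2c1c(-c1ccoc1)cn2[C@@H]1O[C@H](CO)[C@@H](O)[C@H]1O` gives 40 nM. Compound 3 `Nc1nc2c(c(-c3ccoc3)cn2[C@@H]2O[C@H](CO)[C@@H](O)[C@H]2O)c(=O)[nH]1` gives 14200 nM.

Compounds 3 and 1 differ in one place: thiophen-2-yl in place of furan-3-yl on an aromatic carbon. That change made an at least 1.4-fold higher number from compound 3 to compound 1 (0.14 log units; that floor lies within the scatter); the step is known only as a floor because of the limit of > 20000 nM in this assay, at which 1 of the 3 values shown sits. Compound 2 gives the lowest of the two numbers, and the difference between its core and that of compound 3 is not broken down here. Compound 4 `CSc1ncnc2c1c(-c1cccs1)cn2[C@@H]1O[C@H](CO)[C@@H](O)[C@H]1O` has not yet been measured; it differs from compound 2 by thiophen-2-yl in place of furan-3-yl on an aromatic carbon, the same change as from compound 3 to compound 1. Resting on that earlier step, compound 4 is expected to show a 2.0-fold higher number from compound 2 to compound 4 (0.30 log units; within the scatter), and its estimated value in this assay is 80 nM, between 25 nM and 400 nM.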

Compound 4, half-maximal inhibitory concentration: > 20000 nM
Compound 4 gave a limit, no number (the forecaster's own chance of this, stated with the estimate: 3%); middle value at least 250-fold (2.39 log units) from the limit.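

In this assay compound 4 gives > 20000 nM, a limit of the assay and not a number. On the core of compound 2, thiophen-2-yl in place of furan-3-yl gave an at least 500-fold higher number from compound 2 to compound 4 (2.69 log units; beyond the scatter), a large step in the direction also seen on the other core, though there that step is known only as a floor. The result therefore does not show whether the change carries over with the same size or a different one: the same change on two cores in this assay, an at least 1.4-fold higher number (0.14 log units; that floor lies within the scatter) from compound 3 to compound 1 and an at least 500-fold higher number (2.69 log units; beyond the scatter) from compound 2 to compound 4; the limit leaves it open whether they differ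

On these data alone, neither compound 1 nor compound 4 gives a number, so the true size of both steps stays open. Also open, as far as these compounds go, is how either core would respond on that aromatic carbon to a group other than these two rings, such as an amine or a longer chain.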